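Furan in place of fluoromethylphenyl on the shared core

The source may hold more compounds than are shown below. What is called first, only, known or untested is meant among the compounds shown, and "the series" means these compounds.

Two acids share one core and differ only in the distal ring. In a functional assay on CHO cells for agonist activity at Free fatty acid receptor 1 (Homo sapiens), read by FLIPR and calcium flux, in the presence of a further agent that is not named here (a lower number here means that less compound is needed, a higher number that more compound is needed for the effect), compound 1 `O=C(O)CCc1ccc(OCc2ncc(-c3cccc(F)c3)o2)cc1` gives 1070 nM, and compound 2 `Cc1cc(-c2noc(COc3ccc(CCC(=O)O)cc3)n2)ccc1F` gives 2120 nM, the higher of the two numbers, though its gap to compound 1 lies within the scatter. Compound 3 `O=C(O)CCc1ccc(OCc2nc(-c3ccco3)no2)cc1` differs from compound 2 in one place: furan-2-yl in place of 4-fluoro-3-methylphenyl on an aromatic carbon. Among the compounds with values here, no measured pair shows such a step, so compound 3 is expected to need more compound, an estimated step of a 2.1-fold higher number from compound 2 to compound 3 (0.33 log units; beyond the scatter). For compound 3 the estimated value in this assay is 4500 nM, ranging from 1500 nM to 13000 nM.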

Compound 3, half-maximal effective concentration: > 100000 nM
Compound 3 was reported as a limit; the forecaster's own chance of this, stated with the estimate: 15%; middle value at least 22-fold (1.34 log units) from the limit.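

In this assay compound 3 is reported only as a limit, > 100000 nM. Furan-2-yl in place of 4-fluoro-3-methylphenyl, on the aromatic carbon between two ring nitrogen atoms, gives an at least 47-fold higher number from compound 2 to compound 3 (1.67 log units; beyond the scatter), the first sign that the group at this position can decide whether any measurable value is reached. The step is therefore a bound and not a size: the limit of > 100000 nM in this assay, at which 1 of the 3 values shown sits.

On these data alone, it remains open whether the loss goes with the smaller ring, its ring oxygen or the missing fluorine and methyl. An unsubstituted phenyl or a thiophen-2-yl on the same carbon would help separate these.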